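The source may hold more compounds than are shown below. What is called first, only, known or untested is meant among the compounds shown, and "the series" means these compounds.

Measured so far:
compound 1, `COc1cc2c(cc1OC)C(CC(=O)Nc1ccccc1)CC2`, 37.5%
compound 2, `COc1cc2c(cc1OC)C(CC(=O)Nc1cccc(Cl)c1)CC2`, 25.8%
compound 3, `COc1cc2c(cc1OC)C(CC(=O)Nc1ccc(Br)cc1)CC2`, 40.6%

In a functional assay on the whole organism (strain Wistar) for inhibition, with Rattus norvegicus as the target, read by paw edema, with a stated time of 4 h, at a dose of 100 mg/kg (on this read-out higher numbers stand for more inhibition at the one dose given (going by the name of the read-out) and lower numbers for less inhibition), compound 3 gives the highest of the three numbers, though one of its two steps, a number 3.1 percentage points higher from compound 1 to compound 3 (within the scatter), is within the scatter, while the other, a number 14.8 percentage points higher from compound 2 to compound 3 (beyond the scatter), is beyond it. Compound 4, `COc1cc2c(cc1OC)C(CC(=O)Nc1ccc(C)cc1)CC2`, differs from compound 3 by methyl in place of bromo on an aromatic carbon. For the measured compounds named here, no measured step exchanges bromo for methyl. The nearest guide is a number 3.1 percentage points higher from compound 1 to compound 3 (within the scatter), where bromo entering at the same place left the number within the scatter, and a number 14.8 percentage points higher from compound 2 to compound 3 (beyond the scatter), which moved it modestly. The step of a number 2.6 percentage points lower from compound 3 to compound 4 (within the scatter) is therefore expected to stay within the scatter. Compound 4 is estimated at 38%, with a range from 25% to 51%.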

Compound 4, a percentage reported as inhibition, in the whole organism at one dose (the size of the read-out at that dose, not a potency): 32.8%
Beside the measured number, compound 4's estimate is 5.2 percentage points above it; the range from low to high includes it.
By their numbers in this assay, from the lowest: compounds 2, 4, 1 and 3 (each within the scatter of the next, the first and the last beyond it).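

On the aromatic carbon para to a large group, methyl and bromo are not told apart in this assay, a number 7.8 percentage points lower from compound 3 to compound 4 (within the scatter), and methyl is not told apart from hydrogen there either, a number 4.7 percentage points lower from compound 1 to compound 4 (within the scatter). The 4-methylphenyl group also stays within the scatter of 3-chlorophenyl, a number 7 percentage points higher from compound 2 to compound 4 (within the scatter), whereas 4-bromophenyl stood beyond it. Nothing available explains these readings.

From the compounds shown here alone, whether an amine or a carboxylic acid at this place would move the number beyond the scatter of hydrogen remains open.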